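An Aryl Swap on the Ring Nitrogen of Compound 3

A few compounds are considered here, and "the series" means these few. Any claim that something is new, unique, unknown or untested is made for them only; others in the source may bear on it.

Compound 3 `CC#CC(CC(=O)O)c1ccc(OCc2ccc(C(=O)N3CCN(c4ccc([N+](=O)[O-])cc4)CC3)s2)cc1` was tested in a functional assay on HEK293 cells for agonist activity at Free fatty acid receptor 1 (Homo sapiens), read by fluorescence and calcium flux (on this read-out lower numbers stand for an effect already at smaller amounts and higher numbers for an effect only at larger amounts of compound), where compound 3 gives 231 nM. Among the three measured compounds it holds the second highest number. Compound 1 `CC#CC(CC(=O)O)c1ccc(OCc2ccc(C(=O)N3CCN(Cc4ccccc4)CC3)s2)cc1` gives 155 nM in this assay, and compound 2 `CC#CC(CC(=O)O)c1ccc(OCc2ccc(C(=O)N3CCN(c4ccc(C(C)(C)C)cc4)CC3)s2)cc1` gives 417 nM. The step of a 1.5-fold higher number from compound 1 to compound 3 (0.17 log units; within the scatter) lies within the scatter, and so does a 1.8-fold lower number from compound 2 to compound 3 (0.26 log units; within the scatter), whereas a 2.7-fold higher number from compound 1 to compound 2 (0.43 log units; beyond the scatter) goes beyond it.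

Compound 4 `CC#CC(CC(=O)O)c1ccc(OCc2ccc(C(=O)N3CCN(c4cccc(F)c4)CC3)s2)cc1` differs from compound 3 in one place: 3-fluorophenyl in place of 4-nitrophenyl on an amine nitrogen in a ring. The new group sits on an amine nitrogen in a ring of a six-membered non-aromatic ring with 2 nitrogen. For the measured compounds named here, the step of a 1.8-fold lower number from compound 2 to compound 3 (0.26 log units; within the scatter) is the only measured step that exchanges a substituent on the aromatic ring attached to that nitrogen, from tert-butyl to nitro, and it stayed within the scatter. Both measured aryl groups on that ring nitrogen gave numbers close to each other. On this basis the change to 3-fluorophenyl is expected to alter the number only slightly, with a 1.1-fold higher number from compound 3 to compound 4 (0.03 log units; within the scatter) expected to stay within the scatter. Compound 4 is estimated to give 250 nM in this assay, with an expected range from 120 nM to 550 nM.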

Compound 4, half-maximal effective concentration: 97 nM
Beside the measured number, compound 4's estimate is 2.6-fold (0.41 log units) above it; the whole stated range lies above it.
By their numbers in this assay, from the lowest: compounds 4, 1, 3 and 2 (each within the scatter of the next, the first and the last beyond it).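

Compound 4 shows that the aryl group on this amine nitrogen can move the number beyond the scatter, which the exchange of tert-butyl for nitro had not done: in this assay the change to 3-fluorophenyl gives a 2.4-fold lower number from compound 3 to compound 4 (0.38 log units; beyond the scatter) and, against the 4-(tert-butyl)phenyl group, a 4.3-fold lower number from compound 2 to compound 4 (0.63 log units; beyond the scatter). Set against the benzyl group, the same aryl group gives a 1.6-fold lower number from compound 1 to compound 4 (0.20 log units; within the scatter), so an aryl group on this nitrogen can match benzyl within the scatter, although compound 2 goes against any general rule of that kind. Nothing available explains these differences.

The 3-fluorophenyl group differs from the two earlier aryl groups both in its substituent and in where that substituent sits, and the compounds shown do not separate the two, since a plain phenyl or a 4-fluorophenyl on that nitrogen is absent from them. Also open, as far as these compounds go, is whether the number would hold with a larger group in the same place, such as 3-methoxyphenyl or 3-chlorophenyl, or with a pyridine ring in place of the benzene ring.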